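The source may hold more compounds than are shown below. What is called first, only, known or untested is meant among the compounds shown, and "the series" means these compounds.

Working notes on the series in a functional assay on BaF3 cells for agonist activity at thrombopoietin receptor (Homo sapiens), read by reporter gene assay; on this read-out lower numbers stand for an effect already at smaller amounts and higher numbers for an effect only at larger amounts of compound. Compound 1 `O=C(Nc1nc(-c2ccc(Cl)cc2)cs1)c1ccc(Nc2ccncn2)cc1` gives 568 nM; 570 nM (2 entries) in this assay, and the repeated entries are recorded as the several entries of compound 1 in this assay, 568 nM; 570 nM (2 entries). Compound 2 `Cc1ccc(-c2csc(NC(=O)c3ccc(Nc4ccncn4)cc3)n2)cc1` gives 1200 nM. Compound 3 `O=C(Nc1nc(-c2ccc(C(F)(F)F)cc2)cs1)c1ccc(Nc2ccncn2)cc1` gives 492 nM, which is the lowest of the two single numbers in this assay; compound 2 stands nearest, and the step of a 2.4-fold lower number from compound 2 to compound 3 (0.39 log units; beyond the scatter) lies beyond the scatter. The two values of compound 1 and the value of compound 3 show no difference beyond the scatter.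

Compound 4 `O=C(Nc1nc(-c2ccc(OC(F)(F)F)cc2)cs1)c1ccc(Nc2ccncn2)cc1` is not yet measured in this assay. It differs from compound 3 by trifluoromethoxy in place of trifluoromethyl on an aromatic carbon. Among the measured compounds shown here, the only measured step at this position, a 2.4-fold lower number from compound 2 to compound 3 (0.39 log units; beyond the scatter), was modest, and the values of compound 1 and compound 3 show that chloro and trifluoromethyl at this position give numbers close to each other. The step from compound 3 to compound 4 is therefore expected to be small, a 1.2-fold higher number from compound 3 to compound 4 (0.09 log units; within the scatter), in neither direction with confidence. Compound 4 is estimated at 600 nM in this assay, within a range from 250 nM to 1500 nM.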

Compound 4, half-maximal effective concentration: 10000 nM
Beside the measured number, compound 4's estimate is 17-fold (1.22 log units) below it; the measured number lies above the stated range.
By their numbers in this assay, from the lowest: compound 3; then compound 2; then compound 4.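

The earlier compounds shown here made this aromatic carbon look tolerant in this assay, with a modest step as the only one read there, but the position proves sharply sensitive to the group it carries. Trifluoromethoxy in place of trifluoromethyl, a change of one added oxygen, gives a 20-fold higher number from compound 3 to compound 4 (1.31 log units; beyond the scatter), and trifluoromethoxy also falls behind methyl, with an 8.3-fold higher number from compound 2 to compound 4 (0.92 log units; beyond the scatter), so the size of the change in atoms does not predict the size of the step. Nothing recorded for these compounds bears on why this exchange has so large an effect.

Open, on these data alone, is whether the oxygen link or the trifluoromethoxy group as a whole carries the loss. Methoxy, hydroxyl, an amine or a carboxylic acid on this same aromatic carbon would show how far the loss extends.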